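A Nitro Group Tested Against Three Close Neighbours

This account rests on a few compounds, and the source may have more. Where it says the series, first, only, none or still open, it means among the compounds named here.

Of the compounds shown here, three sharing one core have been measured in a functional assay on HCT-116 cells (Homo sapiens) for inhibition, read by MTT assay, with a stated time of 48 h; a lower number here means a stronger inhibitor, a higher number a weaker inhibitor. Compound 1 `Brc1ccccc1CSc1nnc(-c2ccncc2)n1-c1ccccc1` gives 20200 nM. Compound 2 `Fc1ccc(CSc2nnc(-c3ccncc3)n2-c2ccccc2)cc1` gives 12800 nM. Compound 3 `Fc1ccc(CSc2nnc(-c3ccncc3)n2-c2ccccc2)c(F)c1` gives 11400 nM. Within this set compound 2 stands second highest of the three numbers: its nearest neighbour is compound 3, with a step of a 1.1-fold lower number from compound 2 to compound 3 (0.05 log units; within the scatter), and its furthest is compound 1, with a step of a 1.6-fold lower number from compound 1 to compound 2 (0.20 log units; within the scatter). The remaining step, a 1.8-fold lower number from compound 1 to compound 3 (0.25 log units; within the scatter), is likewise within the scatter.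

The new compound 4 `O=[N+]([O-])c1cccc(CSc2nnc(-c3ccncc3)n2-c2ccccc2)c1` differs from compound 2 by 3-nitrophenyl in place of 4-fluorophenyl on a saturated chain carbon bound to a sulfur. The measured steps that bear on it are the two that also exchange the aryl group on that carbon, from compound 1 to compound 2 and from compound 1 to compound 3; both stayed within the scatter. Within the data shown here, no measured compound carries a nitro group, so the expectation rests only on the observation that three different aryl groups at this position gave numbers that cannot be told apart. Compound 4 is therefore expected to yield a step of a 1.0-fold higher number from compound 2 to compound 4 (0.01 log units; within the scatter) in this assay, one that stays within the scatter. The estimated value for compound 4 is 13000 nM, expected to fall between 5000 nM and 35000 nM.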

Compound 4, half-maximal inhibitory concentration: 19800 nM
For compound 4 the middle estimate is 1.5-fold (0.18 log units) below the measured one; the measured number falls inside the stated range.
By their numbers in this assay, from the lowest: compounds 3, 2, 4 and 1 (each within the scatter of the next).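

In this assay, the 3-nitrophenyl group on a saturated chain carbon bound to a sulfur does not separate from any of the three aryl groups measured earlier, with steps of a 1.5-fold higher number from compound 2 to compound 4 (0.19 log units; within the scatter) and a 1.7-fold higher number from compound 3 to compound 4 (0.24 log units; within the scatter) and a 1.0-fold lower number from compound 1 to compound 4 (0.01 log units; within the scatter) all printed as within the scatter. The earlier compounds shown here carried only bromo or fluoro substituents on this aryl group, so compound 4 extends the finding to a nitro group, which brings 9 heavy atoms and 2 hydrogen-bond acceptors where 4-fluorophenyl has 7 heavy atoms and 0 acceptors. Across these four compounds, this change of atoms leaves no difference that can be read, and no measurement at hand bears on why the numbers stay together.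

From the compounds shown here alone, all four compounds keep an aryl group on this carbon and the same shared core, so it remains open whether any change here can move the number beyond the scatter. An amine or a carboxylic acid on the aryl group, or a longer chain in place of the single saturated carbon, would test how far this insensitivity extends.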